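Adding a Phenol to a Series That Shows Only Limits

The compounds below may be only part of what the source reports. "The series", "measured", "known", "first", "only" and "open" are said of these compounds alone.

The shared core is seen in compound 1, `COc1ccc(C(=O)/C=C/c2ccc(F)cc2)c2c1C=CC(C)(C)O2`. In a functional assay on HepG2 cells (Homo sapiens) for antiproliferative activity, read by MTT assay, with a stated time of 24 h (on this read-out lower numbers stand for stronger inhibition and higher numbers for weaker inhibition), compound 1 gives only a limit, > 10000 nM, and not a number. Compound 2, `COc1ccc(C(=O)/C=C/c2ccc(Br)cc2)c2c1C=CC(C)(C)O2`, likewise gives only a limit in this assay, > 10000 nM. Compound 3, `COc1ccc(C(=O)/C=C/c2ccco2)c2c1C=CC(C)(C)O2`, also gives only a limit, > 10000 nM. Because all three sit at the limit of > 10000 nM in this assay, at which 3 of the 3 values shown sit, the steps among them cannot be read: a step that the two limits leave unreadable from compound 1 to compound 2, a step that the two limits leave unreadable from compound 1 to compound 3 and a step that the two limits leave unreadable from compound 2 to compound 3. Compound 4, `COc1ccc(C(=O)/C=C/c2cc(Cl)ccc2O)c2c1C=CC(C)(C)O2`, differs from compound 1 by 5-chloro-2-hydroxyphenyl in place of 4-fluorophenyl on a double-bonded chain carbon bound to a double-bonded chain carbon. Among the compounds with values here, no measured step shows what this change does, so the estimated step that the limit leaves unreadable from compound 1 to compound 4 is expected to be small. Compound 4 is therefore expected to give about 12000 nM, within 3000 nM to 40000 nM, most likely again as a limit.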

Compound 4, half-maximal inhibitory concentration: 6640 nM
Estimate against measurement, compound 4: 1.8-fold (0.26 log units) above, and the stated range covers the measured number.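

Among the four compounds, only compound 4, with 5-chloro-2-hydroxyphenyl on this double-bonded chain carbon, gives a number rather than a limit in this assay. Its steps can be read only as floors: an at least 1.5-fold lower number from compound 1 to compound 4 (0.17 log units; that floor lies within the scatter), an at least 1.5-fold lower number from compound 2 to compound 4 (0.17 log units; that floor lies within the scatter) and an at least 1.5-fold lower number from compound 3 to compound 4 (0.17 log units; that floor lies within the scatter). A real gain at this position is therefore possible, but these floors do not establish one, and the steps among compounds 1, 2 and 3 cannot be read.

As far as these compounds go, it remains open whether the chlorine, the hydroxyl or the two together account for the number. Also open, from the compounds shown here alone, is what an amine or a carboxylic acid would do in place of the hydroxyl.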